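The source may report more compounds than this note shows. Statements on the series, on what has been measured and on what is new or still open speak of the compounds shown alone.

Of the compounds shown here, two that share one core have been tested in a functional assay on the whole organism (strain Wistar albino) for inhibition, with Rattus norvegicus as the target, read by paw edema, with stated times of 30 min and 1 h, at a dose of 10 mg/kg by the oral route; a higher number here means more inhibition at the dose given (going by the name of the read-out), a lower number less inhibition. Compound 1 `COc1ccc(F)cc1-c1cccc(-c2nn(CCCC#N)c(=O)o2)c1` gives 44%, and compound 2 `COc1ccc(F)cc1-c1cccc(-c2nn(CCO)c(=O)o2)c1` gives 41%, the lower of the two numbers, although its gap to compound 1 lies within the scatter. Within the data shown here, the one measured step, a number 3 percentage points lower from compound 1 to compound 2 (within the scatter), exchanged cyanomethyl for hydroxy on a saturated chain carbon, two bonds along the chain from an aromatic nitrogen, and left the inhibition number essentially unchanged. Compound 3 `COC(=O)CCCn1nc(-c2cccc(-c3cc(F)ccc3OC)c2)oc1=O` differs from compound 2 at that same place: (methoxycarbonyl)methyl in place of hydroxy on a saturated chain carbon, two bonds along the chain from an aromatic nitrogen. Among the measured compounds shown here, because the only step that bears on this position, a number 3 percentage points lower from compound 1 to compound 2 (within the scatter), stayed within the scatter, a change of similar size is expected here, with no direction beyond the scatter. The expected step from compound 2 to compound 3 is therefore a number 2 percentage points higher from compound 2 to compound 3 (within the scatter). Compound 3 is estimated at 43%, with a range from 28% to 58%.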

Compound 3, a percentage reported as inhibition, in the whole organism at one dose (the size of the read-out at that dose, not a potency): 45%
Compound 3: the middle estimate sits 2 percentage points below what was measured, and the stated range covers the measured number.
By their numbers in this assay, from the lowest: compounds 2, 1 and 3 (each within the scatter of the next).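

In this assay, putting (methoxycarbonyl)methyl in place of hydroxy gives a number 4 percentage points higher from compound 2 to compound 3 (within the scatter), and methoxycarbonyl in place of cyano gives a number 1 percentage points higher from compound 1 to compound 3 (within the scatter). Among these compounds, this position has now carried a chain ending in hydroxy, in a nitrile and in methoxycarbonyl, and no step among them lies beyond the scatter, even though the change from compound 2 to compound 3 brings in a bigger group and removes the only hydrogen-bond donor of the hydroxy. No independent data on these compounds bear on this result. From the compounds shown here alone, whether a carboxylic acid or an amine at the end of the chain, or a longer chain, would move the number beyond the scatter remains open. The numbers also come from a single oral dose, so they leave the potency of these compounds open.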